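Trifluoromethyl for chloro on a urea aryl ring

This account rests on a few compounds, and the source may have more. Where it says the series, first, only, none or still open, it means among the compounds named here.

Measured compounds:
compound 1 `O=C(Nc1cccc(-n2cc(-c3ccncc3)c(-c3ccc(Cl)c(O)c3)n2)c1)Nc1ccc(Cl)c(Cl)c1`: 17900 nM
compound 2 `COc1cc(-c2nn(-c3cccc(NC(=O)c4ccc(Cl)c(C(F)(F)F)c4)c3)cc2-c2ccncc2)ccc1Cl`: > 32500 nM
compound 3 `O=C(Nc1cccc(-n2cc(-c3ccncc3)c(-c3ccc(Cl)c(O)c3)n2)c1)Nc1cc(C(F)(F)F)cc(C(F)(F)F)c1`: 14000 nM

These three compounds were tested in a functional assay on T47D cells (Homo sapiens) for inhibition, read by sulforhodamine B assay, with a stated time of 48 h; on this read-out higher numbers stand for weaker inhibition of growth and lower numbers for stronger inhibition of growth. Compound 1 gives 17900 nM, the higher of the two plain numbers recorded. Compound 3 gives 14000 nM, and the gap between compound 3 and compound 1 lies within the scatter, so the two cannot be told apart. For compound 2 the result is only a limit, (the limit of > 32500 nM in this assay, at which 1 of the 3 values shown sits), not a number.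

Compound 4 `O=C(Nc1cccc(-n2cc(-c3ccncc3)c(-c3ccc(Cl)c(O)c3)n2)c1)Nc1ccc(Cl)c(C(F)(F)F)c1` is not yet measured. It comes from compound 1 by one change: trifluoromethyl in place of chloro on an aromatic carbon. Among the compounds in hand, compound 3 carries trifluoromethyl groups on the same ring and sits within the scatter of compound 1, which gives no hint of a change beyond the scatter. The step expected from compound 1 to compound 4 is therefore a 1.1-fold lower number from compound 1 to compound 4 (0.05 log units; within the scatter), essentially none. Compound 4 is expected to give about 16000 nM in this assay, with a likely range from 7000 nM to 32000 nM.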

Compound 4, concentration for total growth inhibition: > 32500 nM
Compound 4 ended at the assay's limit (the forecaster's own chance of this, stated with the estimate: 15%); middle value at least 2.0-fold (0.30 log units) from the limit.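

In this assay compound 4 gives > 32500 nM, which is a limit of the assay and not a number. Among these compounds, this is the first direct reading of trifluoromethyl in place of chloro at this position, with the rest of the molecule unchanged, and it gives an at least 1.8-fold higher number from compound 1 to compound 4 (0.25 log units; that floor lies within the scatter), so only a floor for the step is known and the change brings no sign of stronger inhibition of growth. Such a limit is not a lone case in this small set: the limit of > 32500 nM in this assay, at which 2 of the 4 values shown sit.

On these data alone, how far compound 4 truly lies from compound 1 stays open, since the limit hides its real value. Also open is how a methyl group or an amine at this same position would read, as the compounds shown offer only chloro and trifluoromethyl there.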